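The compounds below may be only part of what the source reports. "The series", "measured", "known", "first", "only" and "open" are said of these compounds alone.

Measured in a functional assay on A2780 cells (Homo sapiens) for antiproliferative activity; on this read-out higher numbers stand for weaker inhibition and lower numbers for stronger inhibition:
- compound 1 `NC1CCN(Cc2ccn3ncnc(Nc4ccccc4)c23)CC1`: 3700 nM
- compound 2 `CC(C)Nc1ncnn2ccc(CN3CCC(N)CC3)c12`: "not determined" (no result reported)
- compound 3 `NC1CCN(Cc2ccn3ncnc(Nc4cccc(F)c4)c23)CC1`: > 5000 nM (a limit)

Compound 3 has no single number, only the limit > 5000 nM. Compound 4 `NC1CCN(Cc2ccn3ncnc(Nc4cccc(Cl)c4)c23)CC1` is still to be measured and carries chloro in place of fluoro on an aromatic carbon, meta to a large group (chloro in place of fluoro on an aromatic carbon). Among the measured compounds shown here, one measured step bears on this place, an at least 1.3-fold higher number from compound 1 to compound 3 (0.13 log units; that floor lies within the scatter). That step is only a floor, so it gives no firm size and no clear direction. With so little to go on, a move beyond the scatter in this assay is not expected, and the estimated change is an at least 1.2-fold lower number from compound 3 to compound 4 (0.09 log units; that floor lies within the scatter). For compound 4 the expected value is 4000 nM, with an estimated range of 1500 nM to 9000 nM.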

Compound 4, half-maximal inhibitory concentration: > 5000 nM
Compound 4: only a limit was reported (the forecaster's own chance of this, stated with the estimate: 45%); middle value at least 1.2-fold (0.09 log units) from the limit.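

In this assay chloro, like fluoro, gives only a limit at this aromatic carbon, so neither halogen yields a single number. Chloro in place of hydrogen gives an at least 1.3-fold higher number from compound 1 to compound 4 (0.13 log units; that floor lies within the scatter), which fixes no firm size or direction. The step from fluoro to chloro cannot be read, because compound 3 and compound 4 both sit at the limit: the limit of > 5000 nM in this assay, at which 2 of the 4 values shown sit.

Open, going by these compounds, is how far the true values of compound 3 and compound 4 lie past that limit. Also open, on these data alone, is whether a methoxy group or an amine at this place would give a measurable value.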